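A few compounds are considered here, and "the series" means these few. Any claim that something is new, unique, unknown or untested is made for them only; others in the source may bear on it.

Compound 1, with the structure `COc1cc(NC(=O)Nc2cc(Nc3ccc(C(C)(C)C)cc3)ncn2)cc(OC)c1`, gives 74.1% in a functional assay on PC-9 cells (Homo sapiens) for inhibition, read by MTT assay, with a stated time of 48 h, tested at 10 uM; on this read-out lower numbers stand for less inhibition and higher numbers for more inhibition at the one concentration tested (going by the name of the read-out). On the numbers shown, compound 1 sits at the lower end of the pair, but the gap to compound 2, whose structure is `COc1cc(NC(=O)Nc2cc(Nc3cc(C(F)(F)F)ccc3OC)ncn2)cc(OC)c1` and which gives 81.1% in this assay, lies within the usual scatter of the method, so the two readings cannot be told apart.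

Compound 3, with the structure `COc1cc(NC(=O)Nc2cc(Nc3ccc(Br)cc3OC)ncn2)cc(OC)c1`, has not yet been measured. It differs from compound 1 in a single place: 4-bromo-2-methoxyphenyl in place of 4-(tert-butyl)phenyl on a nitrogen on an aromatic ring. Going by the values given here, no step between two measured compounds is available to guide the size of this change.

Both measured compounds sit at a similar level, so compound 3 is expected to land near them too. The step of a number 1.9 percentage points higher from compound 1 to compound 3 (within the scatter) is expected to stay within the scatter, in no clear direction. For compound 3 the estimate in this assay is 76%, within a range from 58% to 90%.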

Compound 3, a percentage reported as inhibition, at one concentration (the size of the read-out at that concentration, not a potency): 83%
The estimate for compound 3 lay 7 percentage points below the measured number; low and high end bracket the measured number.
By their numbers in this assay, from the lowest: compounds 1, 2 and 3 (each within the scatter of the next).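

Putting 4-bromo-2-methoxyphenyl in place of 4-(tert-butyl)phenyl on a nitrogen on an aromatic ring gives a number 8.9 percentage points higher from compound 1 to compound 3 (within the scatter) in this assay. Going by these compounds alone, this is the first single-place comparison at this position, and it shows that a group of carbon only and a group carrying bromine and oxygen, with a hydrogen-bond acceptor, cannot be told apart here. No measurement shown explains this outcome.

Going by these compounds, the swap alters several features at once, so the separate parts played by the bromine, the methoxy and the loss of tert-butyl remain open. On these data alone, it also remains open whether this position would accept a very different group, such as a phenyl ring carrying a carboxylic acid or an amine, at this level of inhibition.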